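Replacing a Hydroxy Group with a Pyrrolidine Substituent

This account rests on a few compounds, and the source may have more. Where it says the series, first, only, none or still open, it means among the compounds named here.

Compound 1 `CS(=O)(=O)N1CCC(CN(c2nc3cc(F)c(Cl)cc3[nH]2)[C@@H]2CC[C@]3(c4cccc(C#N)c4)C[C@@H]3C2)CC1`: in an assay on isolated protein for binding affinity to melanin-concentrating hormone receptor 1 (Homo sapiens) (a higher number here means a weaker inhibitor, a lower number a stronger inhibitor), compound 1 gives 6.7 nM.
Compound 2 `CN1CCN(CCCN(c2nc3cc(Cl)c(Cl)cc3[nH]2)[C@@H]2CC[C@]3(c4cccc(C#N)c4)C[C@H]23)CC1`: compound 2 gives 6.8 nM.
Compound 3 `CN1CCN(CCCN(c2nc3cc(F)c(F)cc3[nH]2)[C@@H]2CC[C@]3(c4cccc(CO)c4)C[C@@H]3C2)CC1`: compound 3 gives 70.8 nM.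

Of the three measured compounds, compound 3 stands with the highest number, and the gaps to compound 2 and to compound 1 are both beyond the usual scatter of this assay, so compound 3 is the weakest binder among them. Compounds 1 and 2 carry a nitrile on their pendant aromatic ring where compound 3 carries a hydroxymethyl group, but the compounds also differ elsewhere, so no single change can be read from them.

Compound 4 `CN1CCN(CCCN(c2nc3cc(F)c(F)cc3[nH]2)[C@@H]2CC[C@]3(c4cccc(CN5CCC[C@H]5CO)c4)C[C@@H]3C2)CC1` is built from compound 3 by one change: 2-(hydroxymethyl)pyrrolidin-1-yl in place of hydroxy on a saturated chain carbon bound to an aromatic carbon. Among the measured compounds shown here, no measured pair shows this kind of change, so there is no direct guide to its size or direction. The expectation is that the step from compound 3 to compound 4 is modest, a 1.8-fold lower number from compound 3 to compound 4 (0.25 log units; within the scatter), towards a somewhat lower number, but a result within the scatter would not be surprising. The value for compound 4 is estimated at 40 nM, within a range from 10 nM to 160 nM.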

Compound 4, inhibition constant: 3000 nM
For compound 4 the middle estimate is 75-fold (1.88 log units) below the measured one; measured number outside the range, above it.
By their numbers in this assay, from the lowest: compounds 1 and 2 (each within the scatter of the next); then compound 3; then compound 4.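

In this assay, putting 2-(hydroxymethyl)pyrrolidin-1-yl in place of hydroxy on a saturated chain carbon bound to an aromatic carbon gives a 42-fold higher number from compound 3 to compound 4 (1.63 log units; beyond the scatter) as a large step, so this position does not accept every substituent without a heavy cost in binding. Among the compounds shown here, this is the first change in the set made in one place only, and it puts a size on the swap that the earlier compounds, which differ in several places at once, could not show. No measurement shown here accounts for the loss, and its reason stays unknown.

The compounds shown leave open which part of the new group goes with the loss, whether its ring, its nitrogen or its hydroxymethyl arm, and this single step cannot separate them. A plain pyrrolidin-1-yl or a dimethylamino group on the same carbon, or a carboxylic acid in place of the hydroxymethyl group of compound 3, would begin to tell these parts apart.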